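The source may hold more compounds than are shown below. What is called first, only, known or untested is meant among the compounds shown, and "the series" means these compounds.

Compounds measured so far:
- Compound 1 `Cc1ccc(-c2nnc(C3=C(Cl)c4cc(C)c(C)cc4CCC3)o2)cc1`: 2470 nM
- Compound 2 `Cc1cc2c(cc1C)C(Cl)=C(c1nnc(-c3cccc(Cl)c3)o1)CCC2`: 1970 nM

In a functional assay on A549 cells (Homo sapiens) for antiproliferative activity, read by sulforhodamine B assay, with a stated time of 48 h (on this read-out higher numbers stand for weaker inhibition of growth and lower numbers for stronger inhibition of growth), compound 2 gives 1970 nM and stands level, within the scatter, with compound 1 at 2470 nM. Compound 3 `Cc1cc2c(cc1C)C(Cl)=C(c1nnc(-c3cccc(I)c3)o1)CCC2` is the next to be tested. It departs from compound 2 by a single change, iodo in place of chloro on an aromatic carbon, meta to a large group. Within the data shown here, only one measured step bears on this, a 1.3-fold lower number from compound 1 to compound 2 (0.10 log units; within the scatter). Among the measured compounds shown here, that step also alters a substituent on the phenyl group, but it is a different exchange, and no iodo compound has yet been measured. The evidence therefore gives no direction, and no shift beyond the scatter is expected in this assay. The expected step is a 1.1-fold lower number from compound 2 to compound 3 (0.04 log units; within the scatter). For compound 3 the estimated value is 1800 nM, with an expected range from 800 nM to 4000 nM.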

Compound 3, concentration for 50% growth inhibition: 2780 nM
Beside the measured number, compound 3's estimate is 1.5-fold (0.19 log units) below it; the range from low to high includes it.
By their numbers in this assay, from the lowest: compounds 2, 1 and 3 (each within the scatter of the next).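

In this assay, the first exchange measured at this place itself, chloro to iodo meta to a large group, gives a 1.4-fold higher number from compound 2 to compound 3 (0.15 log units; within the scatter) and so leaves the two compounds level within the scatter. Set against the 4-methylphenyl compound, the 3-iodophenyl group gives a 1.1-fold higher number from compound 1 to compound 3 (0.05 log units; within the scatter) and so is also level, which means that all three aryl groups shown, 4-methylphenyl, 3-chlorophenyl and 3-iodophenyl, fall within the scatter of one another. No measurement shown offers an explanation for this result.

The compounds shown leave open whether an amine or a carboxylic acid on this phenyl group would move the number beyond the scatter. They also leave open whether a methoxy group at this place would stay level with chloro and iodo.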